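A few compounds are considered here, and "the series" means these few. Any claim that something is new, unique, unknown or untested is made for them only; others in the source may bear on it.

Measured so far in a functional assay on MGC-803 cells (Homo sapiens) for inhibition, read by MTT assay, with a stated time of 72 h; a higher number here means a weaker inhibitor, a lower number a stronger inhibitor:
compound 1 `COc1cccc(NC(=O)CSc2nc(Nc3ccccc3)c3ccccc3n2)c1`, with 10000 nM
compound 2 `O=C(CSc1nc(Nc2ccccc2)c2ccccc2n1)Nc1ccc(F)cc1`, for which the value is an assay limit rather than a number, > 50000 nM
compound 3 `C=CC(=O)Nc1cccc(NC(=O)CSc2nc(Nc3cccc(OC)c3)c3ccccc3n2)c1`, with 24200 nM

Compound 1 and compound 2 share a core and differ only by 4-fluorophenyl in place of 3-methoxyphenyl on an amide-type nitrogen. Among the measured compounds shown here, the step of an at least 5.0-fold higher number from compound 1 to compound 2 (0.69 log units; beyond the scatter) is the one measured instance of this change. That the value of compound 2 is a limit is recorded as the limit of > 50000 nM in this assay, at which 1 of the 3 values shown sits.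

How the core of compound 3 differs from that of compound 1 is not broken down here. Compound 3 sits at the higher end of the two numbers, and its gap from compound 1 is beyond the scatter.

Compound 4 `C=CC(=O)Nc1cccc(NC(=O)CSc2nc(Nc3ccc(F)cc3)c3ccccc3n2)c1` is not yet measured. It differs from compound 3 by 4-fluorophenyl in place of 3-methoxyphenyl on a nitrogen on an aromatic ring. The place is not the same as for compound 1 to compound 2: there the change sat on an amide-type nitrogen whose other neighbours are carbonyl carbon, here on a nitrogen on an aromatic ring whose other neighbours are aromatic carbon, so it is the same kind of change, not the same change.

Going from compound 3, the step is expected at a 3.3-fold higher number from compound 3 to compound 4 (0.52 log units; beyond the scatter), beside the measured at least 5.0-fold higher number from compound 1 to compound 2 (0.69 log units; beyond the scatter), resting on that step and on compound 3 at 24200 nM, which already stands high. Compound 4 is therefore estimated at 80000 nM, between 30000 nM and 250000 nM, with a good chance that this assay returns only a limit.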

Compound 4, half-maximal inhibitory concentration: 8290 nM
Beside the measured number, compound 4's estimate is 9.7-fold (0.98 log units) above it, outside the stated range (below it).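

In this assay the replacement of 3-methoxyphenyl by 4-fluorophenyl gives a 2.9-fold lower number from compound 3 to compound 4 (0.47 log units; beyond the scatter) and runs in the opposite direction to the earlier step, so the two do not agree: the same change on two cores in this assay, an at least 5.0-fold higher number (0.69 log units; beyond the scatter) from compound 1 to compound 2 and a 2.9-fold lower number (0.47 log units; beyond the scatter) from compound 3 to compound 4, at least 14-fold (1.16 log units) apart, beyond the scatter of two such steps

Compound 2 stands at > 50000 nM as a limit of the assay and not a number, so the earlier step has a bound and no exact size. In these two pairs the direction of the change does not carry from the core of compound 1 to the core of compound 3, but the place also differs, an amide-type nitrogen in one pair and a nitrogen on an aromatic ring in the other, and the pairs do not show whether core or place decides the outcome, nor do two pairs give a rule for the series.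

Open, from the compounds shown here alone, is whether the lower number in compound 4 holds for other groups at that nitrogen, such as 4-chlorophenyl or a phenyl ring bearing a carboxylic acid. Also open, going by these compounds, is how the same replacement behaves at each of the two places on a single core, which would separate place from core.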